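Adding a methoxy group to a paw-edema compound

The compounds below may be only part of what the source reports. "The series", "measured", "known", "first", "only" and "open" are said of these compounds alone.

Measured so far:
compound 1 `C=CCn1c(SCC(=O)c2ccccc2)nnc1-c1ccccc1` gives 66%
compound 2 `C=CCn1c(SC/C(=N\O)c2ccccc2)nnc1-c1ccc(OC)c(OC)c1` gives 69%

Both compounds were tested in a functional assay on the whole organism (strain albino) for inhibition, with Rattus norvegicus as the target, read by paw edema, with a stated time of 5 h, at a dose of 0.28 mmol/kg by the oral route; on this read-out higher numbers stand for more inhibition at the one dose given (going by the name of the read-out) and lower numbers for less inhibition. Compound 1 gives 66% there, and compound 2 gives 69%, a difference within the usual scatter of repeated measurements, so the two numbers are level on these measurements alone.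

Compound 3 `C=CCn1c(SCC(=O)c2ccccc2)nnc1-c1ccc(OC)cc1` has not yet been measured in this assay. It differs from compound 1 in one place: methoxy in place of hydrogen on an aromatic carbon. Since compound 2, which carries methoxy groups on the corresponding ring, gives 69%, close to compound 1, the step from compound 1 to compound 3 is expected to be small, with no change beyond the scatter. The expected step of a number 2 percentage points higher from compound 1 to compound 3 (within the scatter) reflects this. Compound 3 is therefore estimated at 68%, in a range of 55% to 80%.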

Compound 3, a percentage reported as inhibition, in the whole organism at one dose (the size of the read-out at that dose, not a potency): 61%
Beside the measured number, compound 3's estimate is 7 percentage points above it, and the stated range covers the measured number.
By their numbers in this assay, from the lowest: compounds 3, 1 and 2 (each within the scatter of the next).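

Within the data shown here, compound 1 and compound 3 differ in one place only, which gives the first clean reading of this change, phenyl to 4-methoxyphenyl. In this assay, placing methoxy on an aromatic carbon, para to a large group, gives a number 5 percentage points lower from compound 1 to compound 3 (within the scatter), so the two compounds are level and this position accepts the added group without a readable loss. Compound 2 could not show this, since it differs from compound 1 in more than one place, and no measurement shown here offers an explanation for the size of the step.

The compounds shown leave open whether a different group in this same place, such as an amine, a carboxylic acid or a longer chain, would move the number beyond the scatter. They also leave open how methoxy behaves elsewhere on this ring.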